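A Nitrophenyl Group Replaces an Ester-Bearing Phenyl Group

The source may report more compounds than this note shows. Statements on the series, on what has been measured and on what is new or still open speak of the compounds shown alone.

For the measured compounds named here, in a functional assay on SK-OV-3 cells (Homo sapiens) for inhibition, read by CCK-8 assay, with a stated time of 70 h (on this read-out higher numbers stand for weaker inhibition and lower numbers for stronger inhibition), compound 1 `COc1ccc(OCCOCCNC2CCCC2)cc1` reads 99100 nM as the highest number so far. Compound 2 `Nc1ccccc1COc1ccc(OCCOCCNC2CCCC2)cc1` reads 14000 nM as the lowest. Compound 3 `COC(=O)c1cccc(COc2ccc(OCCOCCNC3CCCC3)cc2)c1` reads 45500 nM and so stands in the middle of the three.

Placing a substituted phenyl group on the chain carbon gave a 7.1-fold lower number from compound 1 to compound 2 (0.85 log units; beyond the scatter) with 2-aminophenyl and a 2.2-fold lower number from compound 1 to compound 3 (0.34 log units; beyond the scatter) with 3-(methoxycarbonyl)phenyl, and both steps are modest. The two substituted compounds lie apart by a 3.3-fold higher number from compound 2 to compound 3 (0.51 log units; beyond the scatter) as another modest step.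

Compound 4 `O=[N+]([O-])c1ccccc1COc1ccc(OCCOCCNC2CCCC2)cc1` carries 2-nitrophenyl in place of 3-(methoxycarbonyl)phenyl on a saturated chain carbon bound to an oxygen on an aromatic ring, a change counted as 2-nitrophenyl in place of 3-(methoxycarbonyl)phenyl on a saturated chain carbon bound to an oxygen on an aromatic ring and not yet tested. Going by the values given here, no measured step makes this exact swap, so the only guidance is the narrow spread of the two substituted compounds. A third phenyl group on that carbon is therefore expected to land in the same stretch of numbers.

The expected change in this assay is a 1.5-fold lower number from compound 3 to compound 4 (0.18 log units; within the scatter) and slightly downward, with no step beyond the scatter anticipated. Compound 4 is estimated at 30000 nM with an expected range from 11000 nM to 75000 nM for now.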

Compound 4, half-maximal inhibitory concentration: 5370 nM
Estimate against measurement, compound 4: 5.6-fold (0.75 log units) above; measured number outside the range, below it.
By their numbers in this assay, from the lowest: compound 4; then compound 2; then compound 3; then compound 1.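

In this assay, for the compounds shown here, the group on the saturated chain carbon bound to an oxygen on an aromatic ring matters more than the earlier compounds suggested: 2-nitrophenyl in place of 3-(methoxycarbonyl)phenyl gives an 8.5-fold lower number from compound 3 to compound 4 (0.93 log units; beyond the scatter), a wider step than the one separating the two earlier substituted compounds. The substituent on that phenyl group also counts, not just the presence of a phenyl group, as nitro in place of amino on an aromatic carbon gives a 2.6-fold lower number from compound 2 to compound 4 (0.42 log units; beyond the scatter). Against the hydrogen of the starting compound, the change gives an 18-fold lower number from compound 1 to compound 4 (1.27 log units; beyond the scatter), the first large step here, and compound 4 now has the lowest number, with its steps to all three others beyond the scatter. Nothing shown here explains why the nitro compound reads lower than the others.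

On these data alone, it remains open whether the nitro group itself or its place on the ring accounts for the step from the ester compound: 2-nitrophenyl and 3-(methoxycarbonyl)phenyl differ in both, and a 3-nitrophenyl group would separate the two. As far as these compounds go, it is equally open whether a nitrile or a carboxylic acid in place of the nitro group would read like nitro or like amino.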